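Enone sulfides: swapping the thiophene for methoxyphenyl

A few compounds are considered here, and "the series" means these few. Any claim that something is new, unique, unknown or untested is made for them only; others in the source may bear on it.

Three measured members of this series are compound 1 `Cc1ccc(/C=C(/SCc2ccc(Cl)cc2)C(=O)c2ccc(Cl)cc2)s1`, compound 2 `Cc1ccc(CS/C(=C/c2ccc(C)s2)C(=O)c2ccc(Cl)cc2)cc1` and compound 3 `COc1ccc(S/C(=C/c2ccc(C)s2)C(=O)c2ccc(Cl)cc2)cc1`. In a functional assay on DU-145 cells (Homo sapiens) for inhibition, read by trypan blue exclusion, with a stated time of 96 h (a lower number here means a stronger inhibitor of growth, a higher number a weaker inhibitor of growth), compound 1 gives 50000 nM, compound 2 gives 50000 nM and compound 3 gives 50000 nM. Compound 1 stands level with both companions: the step of no change at the digits printed from compound 1 to compound 2 (within the scatter) and the step of no change at the digits printed from compound 1 to compound 3 (within the scatter) are both flat, as is no change at the digits printed from compound 2 to compound 3 (within the scatter).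

Compound 4 `COc1ccc(/C=C(/SCc2ccc(Cl)cc2)C(=O)c2ccc(Cl)cc2)cc1` has not yet been measured. It differs from compound 1 by 4-methoxyphenyl in place of 5-methylthiophen-2-yl on a double-bonded chain carbon bound to a double-bonded chain carbon. Within the data shown here, none of the measured steps touches this position; they vary the group on the sulfur and the substituent on the benzoyl ring, and none of them moved this assay beyond the scatter. There is therefore no measured basis for a shift, and the step is expected to be no change at the digits printed from compound 1 to compound 4 (within the scatter) in this assay. Compound 4 is estimated at 50000 nM in this assay, with a range from 25000 nM to 100000 nM.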

Compound 4, concentration for 50% growth inhibition: 10000 nM
Compound 4: middle estimate off by 5.0-fold (0.70 log units), on the high side, and the stated range ends above it.
By their numbers in this assay, from the lowest: compound 4; then compounds 1, 2 and 3 (each within the scatter of the next).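

Among these compounds, the group on the double-bonded chain carbon bound to a double-bonded chain carbon is the first place where this assay moves beyond the scatter: 4-methoxyphenyl in place of 5-methylthiophen-2-yl gives a 5.0-fold lower number from compound 1 to compound 4 (0.70 log units; beyond the scatter), whereas the changes on the sulfur and the methyl-for-chloro change left the numbers flat. This pair keeps the 4-chlorobenzyl on the sulfur and the rest of the core of compound 1, so the shift belongs to this single swap. Nothing measured here accounts for the shift.

On these data alone, whether it follows from the six-membered aromatic ring or from the methoxy group remains open, as does whether it persists with other groups on the sulfur. An unsubstituted phenyl or a 4-hydroxyphenyl at this place would begin to separate these possibilities.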